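Methoxy to Hydroxy: A One-Atom Change and Its Expected Effect

The source may report more compounds than this note shows. Statements on the series, on what has been measured and on what is new or still open speak of the compounds shown alone.

Compound 1 `O=C(Nc1cccc(-n2cc(-c3ccncc3)c(-c3ccc(Cl)c(O)c3)n2)c1)Nc1cccc(C(F)(F)F)c1` gives 1490 nM in a functional assay on MDA-MB-435 cells (Homo sapiens) for inhibition, read by sulforhodamine B assay, with a stated time of 48 h; on this read-out lower numbers stand for stronger inhibition and higher numbers for weaker inhibition.
Compound 2 `O=C(Nc1cccc(-n2cc(-c3ccncc3)c(-c3ccc(Cl)c(O)c3)n2)c1)Nc1ccc(Cl)c(Cl)c1` gives 1100 nM in this assay.
Compound 3 `COc1cc(-c2nn(-c3cccc(NC(=O)Nc4ccc(Cl)c(C(F)(F)F)c4)c3)cc2-c2ccncc2)ccc1Cl` gives 680 nM in this assay.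

Compound 3 has the lowest number of the three; its gap to compound 2 is within the scatter, and only its gap to compound 1 is beyond it. Compound 4 `O=C(Nc1cccc(-n2cc(-c3ccncc3)c(-c3ccc(Cl)c(O)c3)n2)c1)Nc1ccc(Cl)c(C(F)(F)F)c1` differs from compound 3 in one place: hydrogen in place of methyl on an oxygen on an aromatic ring, that is, methoxy to hydroxy, or 4-chloro-3-methoxyphenyl to 4-chloro-3-hydroxyphenyl. Within the data shown here, no measured pair differs in exactly this way. Among the measured compounds shown here, the only measured step, a 1.4-fold lower number from compound 1 to compound 2 (0.13 log units; within the scatter), concerns a group on an amide-type nitrogen and sits within the scatter, so it says little about the change at hand. Compounds 1 and 2 carry the hydroxy group and their values in this assay lie close to one another and somewhat above that of compound 3. Compound 4 is therefore expected to give 950 nM in this assay, with a range of 450 nM to 2000 nM. The expected step, a 1.4-fold higher number from compound 3 to compound 4 (0.15 log units; within the scatter), is estimated to stay within the scatter.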

Compound 4, half-maximal inhibitory concentration: 660 nM
Compound 4: middle estimate off by 1.4-fold (0.16 log units), on the high side; low and high end bracket the measured number.
By their numbers in this assay, from the lowest: compounds 4, 3, 2 and 1 (each within the scatter of the next, the first and the last beyond it).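

In this assay, replacing methoxy with hydroxy on this aromatic ring gives a 1.0-fold lower number from compound 3 to compound 4 (0.01 log units; within the scatter), so this direct pair shows that the methyl on this oxygen can go without a measurable change in the number. With the hydroxy group kept, trifluoromethyl in place of chloro on an aromatic carbon gives a 1.7-fold lower number from compound 2 to compound 4 (0.22 log units; within the scatter) and stays within the scatter, while chloro in place of hydrogen on an aromatic carbon gives a 2.3-fold lower number from compound 1 to compound 4 (0.35 log units; beyond the scatter), a modest step and the only one of these three beyond the scatter. Nothing measured here explains why the number holds when the methyl is lost.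

As far as these compounds go, whether an ethoxy group, a longer chain on this oxygen or an amine in place of the hydroxy would also leave the number unchanged remains open. Also open, from the compounds shown here alone, is whether the swap behaves the same way with other groups on the amide-type nitrogen.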